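The source may report more compounds than this note shows. Statements on the series, on what has been measured and on what is new or still open speak of the compounds shown alone.

- Compound 1 `Nc1ncnc2c1c(-c1ccc(Oc3ccccc3)cc1)cn2C[C@H]1CCCN1C[C@@H](O)CO`: 9540 nM
- Compound 2 `Nc1ncnc2c1c(-c1cc3ccccc3o1)cn2[C@H]1CCN(C[C@@H]2CO2)C1`: 2820 nM
- Compound 3 `Nc1ncnc2c1c(-c1cc3ccccc3o1)cn2[C@H]1CCN(C[C@H]2CO2)C1`: 630 nM

These values come from a functional assay on JeKo-1 cells (Homo sapiens) for antiproliferative activity; on this read-out lower numbers stand for stronger inhibition and higher numbers for weaker inhibition. Compound 1 gives the highest number of the three, with compound 2 nearest to it and compound 3 furthest.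

Compound 4 `Nc1ncnc2c1c(-c1ccc(Oc3ccccc3)cc1)cn2[C@H]1CCN(C[C@@H]2CO2)C1` has not yet been measured. In it, 1-((oxiran-2-yl)methyl)pyrrolidin-3-yl takes the place of (1-(2,3-dihydroxypropyl)pyrrolidin-2-yl)methyl on an aromatic nitrogen: 1-((oxiran-2-yl)methyl)pyrrolidin-3-yl in place of (1-(2,3-dihydroxypropyl)pyrrolidin-2-yl)methyl on an aromatic nitrogen. Going by the values given here, only compound 2 and compound 3 carry the entering group, and the one measured step, a 4.5-fold lower number from compound 2 to compound 3 (0.65 log units; beyond the scatter), goes with the fact that compounds 2 and 3 differ only in the configuration as drawn. Compound 4 is drawn with the configuration of compound 2, so the closer guide is compound 2 at 2820 nM. Both compounds differ from compound 4 elsewhere on the core, which leaves this guide loose. A moderate fall in the number is therefore expected, and the expected step is a 4.3-fold lower number from compound 1 to compound 4 (0.64 log units; beyond the scatter). For compound 4 the estimated value is 2200 nM, with an expected range from 600 nM to 8000 nM.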

Compound 4, half-maximal inhibitory concentration: 1480 nM
Estimate against measurement, compound 4: 1.5-fold (0.17 log units) above; the measured number falls inside the stated range.
By their numbers in this assay, from the lowest: compound 3; then compounds 4 and 2 (each within the scatter of the next); then compound 1.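

In this assay, putting 1-((oxiran-2-yl)methyl)pyrrolidin-3-yl in place of (1-(2,3-dihydroxypropyl)pyrrolidin-2-yl)methyl on an aromatic nitrogen gives a 6.4-fold lower number from compound 1 to compound 4 (0.81 log units; beyond the scatter), so this position responds to a change of the whole group and not only to configuration. Compound 4 at 1480 nM and compound 2 at 2820 nM lie within the scatter of each other, although they differ elsewhere on the core. Compound 4 is drawn with the configuration of compound 2, and a 4.5-fold lower number from compound 2 to compound 3 (0.65 log units; beyond the scatter) goes with a single difference: the fact that compounds 2 and 3 differ only in the configuration as drawn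

The step from compound 1 to compound 4 changes the ring attachment and the oxirane together, so the share of each remains unresolved. Also open, from the compounds shown here alone, are the other configuration on the core of compound 4 and how an acrylamide on the pyrrolidine nitrogen would compare with the oxiranylmethyl group.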